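The source may report more compounds than this note shows. Statements on the series, on what has been measured and on what is new or still open speak of the compounds shown alone.

Compound 3 `CCc1ccc(C(=O)Nc2cccc(-c3oc4cc(-c5ccc(F)cc5)ccc4c(=O)c3O)c2)cc1` shows, in a functional assay on HepG2 cells (Homo sapiens) for antiproliferative activity, read by CCK-8 assay, with a stated time of 72 h (on this read-out lower numbers stand for stronger inhibition and higher numbers for weaker inhibition), 20600 nM, the highest number of the three compounds measured, though its gap to compound 2 `Cc1cccc(C(=O)Nc2cccc(-c3oc4cc(-c5ccc(F)cc5)ccc4c(=O)c3O)c2)c1`, which gives 13500 nM, stays within the scatter; compound 1 `O=C(Nc1cccc(-c2oc3cc(-c4ccc(F)cc4)ccc3c(=O)c2O)c1)c1ccc(F)cc1` gives 9280 nM. The measured steps were a 1.5-fold higher number from compound 1 to compound 2 (0.16 log units; within the scatter), a 2.2-fold higher number from compound 1 to compound 3 (0.35 log units; beyond the scatter) and a 1.5-fold higher number from compound 2 to compound 3 (0.18 log units; within the scatter). Compound 4 `Cc1cc(C(=O)Nc2cccc(-c3oc4cc(-c5ccc(F)cc5)ccc4c(=O)c3O)c2)ccc1F` differs from compound 3 in one place: 4-fluoro-3-methylphenyl in place of 4-ethylphenyl on a carbonyl carbon. The two steps that changed this same phenyl ring moved the numbers only modestly, and compound 4 carries a fluoro on that ring as compound 1 does, so a modest drop in number is expected, a 1.7-fold lower number from compound 3 to compound 4 (0.23 log units; within the scatter). For compound 4 the estimate in this assay is 12000 nM, with a range from 6000 nM to 25000 nM.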

Compound 4, half-maximal inhibitory concentration: 9540 nM
Beside the measured number, compound 4's estimate is 1.3-fold (0.10 log units) above it; low and high end bracket the measured number.
By their numbers in this assay, from the lowest: compounds 1, 4, 2 and 3 (each within the scatter of the next, the first and the last beyond it).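

In this assay, 4-fluoro-3-methylphenyl in place of 4-ethylphenyl on the carbonyl carbon gives a modest step beyond the scatter (a 2.2-fold lower number from compound 3 to compound 4 (0.33 log units; beyond the scatter)), so two rings with the same heavy-atom count can be told apart at this place. Single additions to the ring do not separate: fluoro in place of hydrogen gives (a 1.4-fold lower number from compound 2 to compound 4 (0.15 log units; within the scatter)), and methyl in place of hydrogen gives (a 1.0-fold higher number from compound 1 to compound 4 (0.01 log units; within the scatter)). No evidence here explains the step from the ethyl-bearing ring. Going by these compounds, whether an amine, a carboxylic acid or a longer chain on this ring would change the number remains open.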